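The source may report more compounds than this note shows. Statements on the series, on what has been measured and on what is new or still open speak of the compounds shown alone.

Measured compounds:
Compound 1, `Cc1cccc(NC(=O)c2nc(C)ccc2O)n1`, gives 7 nM in an assay on Ltk cells with metabotropic glutamate receptor 5 (Homo sapiens) as the target, read by fluorescence and calcium flux; a lower number here means a stronger inhibitor, a higher number a weaker inhibitor.
Compound 2, `CCCOc1cccnc1Nc1cccc(C)n1`, gives 1600 nM in this assay.
Compound 3, `CCOc1cc(-c2cccc(F)c2)cnc1Nc1cccc(C)n1`, gives 126 nM in this assay.

Compound 3 sits second highest of the three numbers in this assay. Its nearest neighbour is compound 2, whose number is higher by a margin that lies beyond the scatter; compound 1 lies furthest from it, with a lower number, again beyond the scatter. Compound 1 shares only the (6-methylpyridin-2-yl)amino group with compounds 2 and 3 and is built on a different core, so its value serves as a reference point rather than as a step.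

Compound 4, `CCOc1cc(-c2cccnc2)cnc1Nc1cccc(C)n1`, has not yet been measured in this assay. Compared with compound 3 it differs in one place: pyridin-3-yl in place of 3-fluorophenyl on an aromatic carbon. Among the compounds with values here, the two groups are of nearly the same size, and no measured pair in the set shows what this exchange does. Within the set, the step from compound 2 to compound 3 shows that carrying a six-membered aromatic ring at this place gives a much lower number than carrying none. The expectation for compound 4 is therefore a number in the region of compound 3, with at most a modest rise, as the estimated step of a 1.7-fold higher number from compound 3 to compound 4 (0.24 log units; within the scatter) indicates. The estimate for compound 4 in this assay is 220 nM, with a likely range from 60 nM to 800 nM.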

Compound 4, half-maximal inhibitory concentration: 12 nM
Estimate against measurement, compound 4: 18-fold (1.26 log units) above; the measured number lies below the stated range.
By their numbers in this assay, from the lowest: compounds 1 and 4 (each within the scatter of the next); then compound 3; then compound 2.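

In this assay, the exchange of 3-fluorophenyl for pyridin-3-yl on the aromatic carbon para to the (6-methylpyridin-2-yl)amino group gives an 11-fold lower number from compound 3 to compound 4 (1.02 log units; beyond the scatter), so the number at this place depends on which six-membered aromatic ring is carried there, not merely on the presence of such a ring. The change is a compact one, with a carbon-only ring bearing fluorine leaving and a ring with 1 hetero atom and 1 hydrogen-bond acceptor entering, yet a single pair cannot separate the gain of the ring nitrogen from the loss of the fluorine. Nothing available offers an explanation for the size of this step.

An unsubstituted phenyl at this place would separate those two contributions, while pyridin-4-yl or pyridin-2-yl would show whether the location of the ring nitrogen matters. On these data alone, it also remains open whether the exchange carries over to the propoxy series, or to a pyridin-3-yl ring bearing a fluorine or a methyl group.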